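The source may hold more compounds than are shown below. What is called first, only, known or untested is meant among the compounds shown, and "the series" means these compounds.

Three compounds of a shared core have been examined in an ADME assay on HEK293 cells (Homo sapiens) for cytotoxicity, read by CCK-8 assay and cell counting, with a stated time of 2 days; a lower number here means a stronger inhibitor, a higher number a weaker inhibitor:

Compound 1 `Oc1ccc(-c2cc(-c3ccncc3)nc(-c3ccc(Cl)cc3)c2)cc1`: "not determined" (no result reported)
Compound 2 `Oc1cccc(-c2cc(-c3ccncc3)nc(-c3ccc(Cl)cc3)c2)c1`: 2890 nM
Compound 3 `Oc1ccc(-c2cc(-c3ccncc3)nc(-c3ccccc3Cl)c2)cc1`: "not determined" (no result reported)

Compound 1 stands on no number in this assay; its entry reads only "not determined" (no result reported), and compound 3 likewise has no single number. The one figure in the set comes from compound 2, which in this assay gives 2890 nM. Compound 4 `Oc1ccc(-c2cc(-c3ccccc3)nc(-c3ccc(Cl)cc3)c2)cc1` is the compound still to be measured. The change that leads from compound 1 to compound 4 is phenyl in place of pyridin-4-yl on an aromatic carbon. Among the compounds with values here, no pair of measured compounds shows what this change does, so its size in this assay cannot be read from the data. The expectation is a step of no more than the scatter in either direction, since nothing in the set points one way or the other. The number for compound 2 serves as the only anchor, and the band around the estimate is kept wide for that reason. Compound 4 is therefore expected to give about 3000 nM in this assay, within an estimated range from 800 nM to 12000 nM.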

Compound 4, half-maximal inhibitory concentration: 4810 nM
Compound 4: middle estimate off by 1.6-fold (0.21 log units), on the low side; the range from low to high includes it.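

In this assay, within the data shown here, compound 4 gives 4810 nM and compound 1 gives "not determined" (no result reported) so no step from compound 1 to compound 4 can be read. From the compounds shown here alone, what phenyl in place of pyridin-4-yl does to the value in this assay stays open. No other information here bears on this result.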